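Fluoro to butylcarbamoyl in the growth inhibition series

The source may hold more compounds than are shown below. What is called first, only, known or untested is meant among the compounds shown, and "the series" means these compounds.

Measured in a functional assay on HeLa cells (Homo sapiens) for antiproliferative activity, read by CCK-8 assay, with a stated time of 72 h; a higher number here means a weaker inhibitor of growth, a lower number a stronger inhibitor of growth:
- compound 1 `CCC1C(=O)N(C)c2cnc(-n3ccc4cc(C(=O)NC(C)C)ccc43)nc2N1c1ccn(C)n1` - 4350 nM
- compound 2 `CCC1C(=O)N(C)c2cnc(-n3ccc4cc(F)ccc43)nc2N1c1ccn(C)n1` - "not active" (no number reported)
- compound 3 `CC[C@@H]1C(=O)N(C)c2cnc(-n3ccc4cc(C(=O)NC)ccc43)nc2N1C1CCCC1` - 768 nM

Compound 2 stands apart from the other two: in this assay compound 2 is reported as "not active" (no number reported) and has no single number. Both measured compounds that carry a carbamoyl group in place of the fluoro give numbers. Compound 3 also differs from compound 2 elsewhere on the shared core, so compound 1 is the closer reference.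

Compound 4 `CCCCNC(=O)c1ccc2c(ccn2-c2ncc3c(n2)N(c2ccn(C)n2)C(CC)C(=O)N3C)c1` keeps the rest of compound 2 and has butylcarbamoyl in place of fluoro on an aromatic carbon. This places compound 4 close to compound 1, which gives 4350 nM.

In this assay the change is expected to move compound 4 towards stronger growth inhibition than compound 2 shows. The size of that step cannot be stated, as compound 2 offers no number to count from. Within the data shown here, with only three measured compounds, the estimate is anchored on compound 1 at 4350 nM and carries a wide range. A result with no number also remains possible.

For compound 4 the expected value is 4000 nM, with an estimated range from 1500 nM to 11000 nM.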

Compound 4, concentration for 50% growth inhibition: 4260 nM
Compound 4: the middle estimate sits 1.1-fold (0.03 log units) below what was measured, within the range that was stated.
By their numbers in this assay, from the lowest: compound 3; then compounds 4 and 1 (each within the scatter of the next).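

In this assay compound 4 gives 4260 nM as a number, while compound 2, with fluoro on the same aromatic carbon, is reported as not active; with no number for compound 2, the step between them cannot be read. Compounds 1 and 4 show that this position gives a measurable result with either of two amide chains, and butyl in place of isopropyl on the amide-type nitrogen gives a 1.0-fold lower number from compound 1 to compound 4 (0.01 log units; within the scatter) with no difference that can be read beyond the scatter. Nothing available explains why the fluoro compound and the two amides are reported differently.

Still open, as far as these compounds go, is whether a longer chain such as hexyl, or a butyl chain ending in an amine or a carboxylic acid, would stay level with compounds 1 and 4 or would part from them. Compound 3 carries a methylcarbamoyl group but also differs elsewhere on the shared core, so it does not settle how the length of the amide chain bears on growth inhibition.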